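Replacing Nitro with Azide on a Shared Core

The source may hold more compounds than are shown below. What is called first, only, known or untested is meant among the compounds shown, and "the series" means these compounds.

In a functional assay on MCF7 cells (Homo sapiens) for antiproliferative activity, read by MTT assay, with stated times of 24 h and 72 h (on this read-out lower numbers stand for stronger inhibition and higher numbers for weaker inhibition), compound 1 `COc1cccc([C@@H]2[C@H](Oc3ccccc3)C(=O)N2c2cc(OC)c(OC)c(OC)c2)c1` gives 171000 nM while compound 2 `COc1cc(N2C(=O)[C@@H](Oc3ccccc3)[C@H]2c2cccc([N+](=O)[O-])c2)cc(OC)c1OC` gives 30000 nM and so holds the lower of the two numbers. Compound 3 `COc1cc(N2C(=O)[C@@H](Oc3ccccc3)[C@H]2c2ccc(N=[N+]=[N-])cc2)cc(OC)c1OC` has not been measured yet. It carries 4-azidophenyl in place of 3-nitrophenyl on a saturated ring carbon and keeps the rest of compound 2 unchanged.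

Among the measured compounds shown here, only one measured step offers any guidance. That step is a 5.7-fold lower number from compound 1 to compound 2 (0.76 log units; beyond the scatter) and it came with nitro in place of methoxy on an aromatic carbon. For the measured compounds named here, it is a single modest step, and no measured compound carries an azide, so it suggests a plausible size but no direction. A change of similar size could go either way, so the best single guess is a small one. The expected step of a 1.2-fold lower number from compound 2 to compound 3 (0.08 log units; within the scatter) is estimated to stay within the usual scatter of this assay for now. Compound 3 is therefore estimated at 25000 nM with an expected range from 4000 nM to 120000 nM around that value.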

Compound 3, half-maximal inhibitory concentration: 23000 nM
Estimate against measurement, compound 3: 1.1-fold (0.04 log units) above; measured number inside the range.
By their numbers in this assay, from the lowest: compounds 3 and 2 (each within the scatter of the next); then compound 1.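

In this assay, the step of a 1.3-fold lower number from compound 2 to compound 3 (0.12 log units; within the scatter) shows that this saturated ring carbon accepts 4-azidophenyl in place of 3-nitrophenyl with no difference that can be told apart from the scatter, even though both the group and its number on the phenyl ring change. Set against the 3-methoxyphenyl group, the swap gives a 7.4-fold lower number from compound 1 to compound 3 (0.87 log units; beyond the scatter), so among these three compounds the lower numbers are not tied to nitro alone: compound 2 and compound 3 both lie clearly below compound 1. There is no outside measurement to explain why these groups give these numbers.

Since compound 2 and compound 3 differ in both the group and its number on the phenyl ring, the effects of these two changes cannot be separated, and a comparison of 4-nitrophenyl with 4-azidophenyl or of 3-nitrophenyl with 3-azidophenyl would be needed to do so. The compounds shown also leave open how an amine or a carboxylic acid on the phenyl ring at this position would compare with nitro and azide.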